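The source may hold more compounds than are shown below. What is called first, only, known or untested is meant among the compounds shown, and "the series" means these compounds.

Series built on the shared core of compound 1 `Cc1c(Cc2ccc(Br)cc2)c(=O)oc2cc(OCC(O)CN3CCC(C(N)=O)CC3)ccc12`, compared throughout in an ADME assay on A549 cells (Homo sapiens) for cytotoxicity, read by CellTiter-Glo; on this read-out lower numbers stand for higher toxicity in this test and higher numbers for lower toxicity in this test. For compound 1 the read-out is a limit of the assay, > 100000 nM. Compound 2 `Cc1c(Cc2ccc(OC(F)(F)F)cc2)c(=O)oc2cc(OCC(O)CN3CCC(C(N)=O)CC3)ccc12` gives 68200 nM in this assay. For compound 3 `COC(=O)c1ccc(Cc2c(C)c3ccc(OCC(O)CN4CCC(C(N)=O)CC4)cc3oc2=O)cc1` the read-out is again a limit of the assay, > 100000 nM. Compound 3 thus stands at the limit of > 100000 nM in this assay, at which 2 of the 3 values shown sit, rather than at a number. Compound 4 `COc1ccccc1-c1ccc(Cc2c(C)c3ccc(OCC(O)CN4CCC(C(N)=O)CC4)cc3oc2=O)cc1` is not yet measured and differs from compound 3 by 2-methoxyphenyl in place of methoxycarbonyl on an aromatic carbon. The steps touching compound 3 are a step that the two limits leave unreadable from compound 1 to compound 3 and an at least 1.4-fold higher number from compound 2 to compound 3 (0.16 log units; that floor lies within the scatter), so the substituent swaps seen so far move the number no further than the scatter or leave it at the limit. For compound 4 the step of an at least 1.1-fold lower number from compound 3 to compound 4 (0.04 log units; that floor lies within the scatter) is therefore expected to stay within the scatter. Compound 4 is estimated at 90000 nM, range 30000 nM to 200000 nM.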

Compound 4, half-maximal cytotoxic concentration: 91600 nM
For compound 4 the middle estimate is 1.0-fold (0.01 log units) below the measured one; low and high end bracket the measured number.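

In this assay, the aromatic carbon para to a large group takes 2-methoxyphenyl, with 8 heavy atoms and a six-membered aromatic ring, without a step beyond the scatter: a 1.3-fold higher number from compound 2 to compound 4 (0.13 log units; within the scatter), an at least 1.0-fold lower number from compound 3 to compound 4 (0.03 log units; that floor lies within the scatter) and an at least 1.0-fold lower number from compound 1 to compound 4 (0.03 log units; that floor lies within the scatter). The steps from compound 1 and compound 3 are floors only, since those two compounds remain limits of the assay: the limit of > 100000 nM in this assay, at which 2 of the 4 values shown sit.

Still open, going by these compounds, is whether an amine or a carboxylic acid on this carbon would give a step beyond the scatter.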